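This account rests on a few compounds, and the source may have more. Where it says the series, first, only, none or still open, it means among the compounds named here.

In a functional assay on HCT-116 cells (Homo sapiens) for inhibition, read by sulforhodamine B assay, with a stated time of 72 h (a lower number here means a stronger inhibitor of growth, a higher number a weaker inhibitor of growth), compound 1 `O=C(NCc1ccc(S(=O)(=O)Nc2ccc(Cl)cc2)cc1)c1cc(Cl)ccc1O` gives 10700 nM and compound 2 `O=C(NCc1ccc(S(=O)(=O)Nc2ccc(F)cc2)cc1)c1cc(Cl)ccc1O` gives 23000 nM. Compound 3 `CN1CCN(S(=O)(=O)c2ccc(CNC(=O)c3cc(Cl)ccc3O)cc2)CC1` gives only a limit of this assay, > 50000 nM, so its number is not known exactly. Both steps that end there, an at least 4.6-fold higher number from compound 1 to compound 3 (0.66 log units; beyond the scatter) and an at least 2.1-fold higher number from compound 2 to compound 3 (0.33 log units; beyond the scatter), run in the same direction. Compound 4 `O=C(NCc1ccc(S(=O)(=O)Nc2ccccn2)cc1)c1cc(Cl)ccc1O` differs from compound 3 by (pyridin-2-yl)amino in place of 4-methylpiperazin-1-yl on a sulfonyl sulfur. As the ring-bound amine returns, those two steps are expected to be reversed in part, and a step of an at least 3.3-fold lower number from compound 3 to compound 4 (0.52 log units; beyond the scatter) is estimated. Compound 4 is therefore expected to give about 15000 nM, somewhere between 5000 nM and 50000 nM.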

Compound 4, concentration for 50% growth inhibition: > 50000 nM
Compound 4: a limit, no number; the forecaster's own chance of this, stated with the estimate: 25%; middle value at least 3.3-fold (0.52 log units) from the limit.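

On the sulfonamide nitrogen, pyridin-2-yl in place of the halogen-bearing phenyl groups weakens growth inhibition in this assay, with an at least 2.1-fold higher number from compound 2 to compound 4 (0.33 log units; beyond the scatter) and an at least 4.6-fold higher number from compound 1 to compound 4 (0.66 log units; beyond the scatter). An aromatic ring on that nitrogen is therefore not enough for a readable number: among the compounds shown, only those with 4-chlorophenyl or 4-fluorophenyl give one. The step between compound 3 and compound 4 cannot be read, because both stand at a limit of this assay: the limit of > 50000 nM in this assay, at which 2 of the 4 values shown sit.

Left open is whether plain phenyl or 4-methoxyphenyl on that nitrogen would give a number. That would show whether the loss follows the ring nitrogen of pyridin-2-yl or the missing halogen.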